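This account rests on a few compounds, and the source may have more. Where it says the series, first, only, none or still open, it means among the compounds named here.

Three compounds sharing one core differ only in the amine attached to the carbonyl carbon. In an assay on C6 cells for displacement of a labelled ligand from Translocator protein (Rattus norvegicus), read by scintillation counting, with a stated time of 2 h (a higher number here means a weaker inhibitor, a lower number a stronger inhibitor), compound 1 `CCc1cc(CC)n2nc(-c3ccc(OC)cc3)c(CC(=O)N(C)C)c2n1` gives 37.6 nM, compound 2 `CCCN(CCC)C(=O)Cc1c(-c2ccc(OC)cc2)nn2c(CC)cc(CC)nc12` gives 5.57 nM, and compound 3 `CCc1cc(CC)n2nc(-c3ccc(OC)cc3)c(CC(=O)N(C(C)CC)C(C)CC)c2n1` gives 14.4 nM. Compound 3 therefore stands second highest of the three, with a 2.6-fold higher number from compound 2 to compound 3 (0.41 log units; beyond the scatter) and a 2.6-fold lower number from compound 1 to compound 3 (0.42 log units; beyond the scatter). Compound 4 `CCc1cc(CC)n2nc(-c3ccc(OC)cc3)c(CC(=O)N3CCCC3)c2n1` carries pyrrolidin-1-yl in place of bis(sec-butyl)amino on a carbonyl carbon. Every measured step changes this same amine: a 6.8-fold lower number from compound 1 to compound 2 (0.83 log units; beyond the scatter), a 2.6-fold lower number from compound 1 to compound 3 (0.42 log units; beyond the scatter) and a 2.6-fold higher number from compound 2 to compound 3 (0.41 log units; beyond the scatter), all modest, the smallest amine giving the highest number. Compound 4 is expected to stay close to compound 3, with a 1.2-fold lower number from compound 3 to compound 4 (0.08 log units; within the scatter), because a 2.6-fold higher number from compound 2 to compound 3 (0.41 log units; beyond the scatter) and a 2.6-fold lower number from compound 1 to compound 3 (0.42 log units; beyond the scatter) both remained modest. The estimate for compound 4 in this assay is 12 nM, ranging from 4 nM to 35 nM.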

Compound 4, inhibition constant: 127 nM
Beside the measured number, compound 4's estimate is 11-fold (1.02 log units) below it, outside the stated range (above it).
By their numbers in this assay, from the lowest: compound 2; then compound 3; then compound 1; then compound 4.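

Closing the amine into a ring costs far more than any earlier change at this carbonyl carbon: pyrrolidin-1-yl makes compound 4 the weakest of the four, with steps (an 8.8-fold higher number from compound 3 to compound 4 (0.95 log units; beyond the scatter)) and (a 23-fold higher number from compound 2 to compound 4 (1.36 log units; beyond the scatter)). It also ends the earlier picture of the smallest amine giving the highest number, since the ring sits above dimethylamino (a 3.4-fold higher number from compound 1 to compound 4 (0.53 log units; beyond the scatter)). No supporting measurement accounts for this drop. Still open, as far as these compounds go, is whether the ring itself matters, which piperidin-1-yl or morpholin-4-yl could test. Diethylamino would likewise show how an open-chain amine of intermediate length behaves here.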